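Ethyl acyl chain tested after a cyclopropyl loss

A few compounds are considered here, and "the series" means these few. Any claim that something is new, unique, unknown or untested is made for them only; others in the source may bear on it.

Compound 1 `C/C=C(\C)C(=O)O[C@H]1[C@]2(C)C[C@@H]3O[C@@]1(O)C=C1C4=CC(=O)O[C@@H](c5ccoc5)[C@]4(C)CC[C@@H]1[C@]3(C)[C@@H]2[C@@H](O)C(=O)OC` carries a free hydroxyl on the saturated carbon in question, and in a functional assay on DU-145 cells (Homo sapiens) for inhibition, read by MTT assay, with a stated time of 24 h (a higher number here means a weaker inhibitor, a lower number a stronger inhibitor), compound 1 gives 7700 nM. Compound 2 `C/C=C(\C)C(=O)O[C@@H]1[C@]2(OC(=O)CCCC)C=C3C4=CC(=O)O[C@@H](c5ccoc5)[C@]4(C)CC[C@@H]3[C@@]3(C)[C@H](C[C@]1(C)[C@H]3[C@@H](O)C(=O)OC)O2` bears a butylcarbonyl there, and in this assay compound 2 gives 5200 nM; the step is a 1.5-fold lower number from compound 1 to compound 2 (0.17 log units; within the scatter). Compound 3 `C/C=C(\C)C(=O)O[C@@H]1[C@]2(OC(=O)C3CC3)C=C3C4=CC(=O)O[C@@H](c5ccoc5)[C@]4(C)CC[C@@H]3[C@@]3(C)[C@H](C[C@]1(C)[C@H]3[C@@H](O)C(=O)OC)O2` bears a cyclopropylcarbonyl in the same position. In this assay compound 3 reaches only the limit > 100000 nM, which is not a number. Compound 3 therefore sits at the limit of > 100000 nM in this assay, at which 1 of the 3 values shown sits. Both steps leading into it are large: an at least 12-fold higher number from compound 1 to compound 3 (1.11 log units; beyond the scatter) and an at least 19-fold higher number from compound 2 to compound 3 (1.28 log units; beyond the scatter). Compound 4 `C/C=C(\C)C(=O)O[C@@H]1[C@]2(OC(=O)CC)C=C3C4=CC(=O)O[C@@H](c5ccoc5)[C@]4(C)CC[C@@H]3[C@@]3(C)[C@H](C[C@]1(C)[C@H]3[C@@H](O)C(=O)OC)O2` differs from compound 3 by ethyl in place of cyclopropyl on a carbonyl carbon. Compound 4 thus carries a straight acyl chain, as does compound 2, which stood at 5200 nM. Since the only large steps shown accompany the cyclopropyl, the author expects a return toward the chain compounds, an at least 6.6-fold lower number from compound 3 to compound 4 (0.82 log units; beyond the scatter), though the exact size is uncertain. Compound 4 is accordingly estimated at 15000 nM, within a range from 4000 nM to 100000 nM.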

Compound 4, half-maximal inhibitory concentration: 6700 nM
Compound 4: the middle estimate sits 2.2-fold (0.35 log units) above what was measured; the measured number falls inside the stated range.
By their numbers in this assay, from the lowest: compounds 2, 4 and 1 (each within the scatter of the next). At a limit, above all of these: compound 3.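

Replacing the cyclopropyl with ethyl brings the number back in this assay (an at least 14-fold lower number from compound 3 to compound 4 (1.17 log units; beyond the scatter)), so among these compounds the loss goes with the cyclopropylcarbonyl, not with acylating this oxygen as such. The propanoyl compound cannot be told apart from the butylcarbonyl compound (a 1.3-fold higher number from compound 2 to compound 4 (0.11 log units; within the scatter)) or from the free hydroxyl (a 1.1-fold lower number from compound 1 to compound 4 (0.06 log units; within the scatter)), so both straight acyl chains leave the number within the scatter of the hydroxyl compound, and compound 3 alone goes against this. The value of compound 3 remains a limit of the assay, not a number: the limit of > 100000 nM in this assay, at which 1 of the 4 values shown sits.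

Going by these compounds, whether the loss is particular to cyclopropylcarbonyl or extends to another ring, such as cyclobutylcarbonyl or benzoyl, remains open. So does the response to a chain longer than butylcarbonyl, or to a branched isobutyryl group, at this position.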